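Removing the N-methyl and exchanging acid for carboxamide

This account rests on a few compounds, and the source may have more. Where it says the series, first, only, none or still open, it means among the compounds named here.

Among the three measured compounds, compound 1 `CN(C(=O)c1cc(F)cc2cc(-c3ccc(Cl)cc3)oc12)C(C)(C)C(=O)O` gives 1970 nM in an assay on isolated protein for inhibition of endoplasmic reticulum aminopeptidase 1 (Homo sapiens), with stated times of 15 min and 20 min (a lower number here means a stronger inhibitor, a higher number a weaker inhibitor), the highest of the three numbers; compound 3 `CC(C)(NC(=O)c1cccc2c(Br)c(-c3ccc(Cl)cc3)oc12)C(=O)O` gives 1760 nM and compound 2 `CC(C)(NC(=O)c1cccc2cc(-c3ccc(Cl)cc3)oc12)C(=O)O` gives 1030 nM, both within the scatter of compound 1. Going by the values given here, the only single-point step measured, a 1.7-fold higher number from compound 2 to compound 3 (0.23 log units; within the scatter), concerns a ring substituent and says nothing about the amide end. Compound 4 `CC(C)(NC(=O)c1cc(F)cc2cc(-c3ccc(Cl)cc3)oc12)C(N)=O` differs from compound 1 at that end: (1-carbamoyl-1-methylethyl)amino in place of (1-carboxy-1-methylethyl)(methyl)amino on a carbonyl carbon. Among the compounds with values here, no measured step bears on this change, so the direction is open. Compound 4 is therefore estimated at 4000 nM, between 1000 nM and 20000 nM, a step of a 2.0-fold higher number from compound 1 to compound 4 (0.31 log units; beyond the scatter) that is meant as an uncertain expectation.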

Compound 4, half-maximal inhibitory concentration: > 10000 nM
Compound 4 was reported as a limit; the forecaster's own chance of this, stated with the estimate: 20%; at least 2.5-fold (0.39 log units) between middle value and limit.
By their numbers in this assay, from the lowest: compounds 2, 3 and 1 (each within the scatter of the next). At a limit, above all of these: compound 4.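

In this assay compound 4 gives > 10000 nM, which is a limit of the assay and not a number. The change at the carbonyl carbon comes with an at least 5.0-fold higher number from compound 1 to compound 4 (0.70 log units; beyond the scatter), the first step shown that lies beyond the scatter, so the amide end matters to the number in a way the ring substituent step did not show. This reading rests on a single value: the limit of > 10000 nM in this assay, at which 1 of the 4 values shown sits.

The step joins two changes, so the compounds shown do not tell whether losing the N-methyl or replacing the carboxylic acid with the carboxamide carries it. As far as these compounds go, how a methyl ester or a hydroxamic acid would read at this end also stays open.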